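A few compounds are considered here, and "the series" means these few. Any claim that something is new, unique, unknown or untested is made for them only; others in the source may bear on it.

Working notes on the series. The shared core is carried by compound 1 `CCCCCCNC(=O)n1cc(CC)c(=O)[nH]c1=O`, compound 2 `CCCCCCNC(=O)n1cc(F)c(=O)n(C)c1=O` and compound 3 `CCCCCCNC(=O)n1cc(F)c(=O)n(CC2CC2)c1=O`; compound 4 `CCCCCCNC(=O)n1cc(F)c(=O)n(C(=O)OCC)c1=O` is not yet measured. In an assay on HEK293 cells for inhibition of acid ceramidase (Rattus norvegicus), read by LC-MS, with a stated time of 30 min (a lower number here means a stronger inhibitor, a higher number a weaker inhibitor), compound 1 gives 733 nM, compound 2 gives 13 nM and compound 3 gives 61 nM. Compound 3 thus stands second highest of the three numbers, nearest to compound 2 and furthest from compound 1. Among the measured compounds shown here, the one single-point step measured so far, a 4.7-fold higher number from compound 2 to compound 3 (0.67 log units; beyond the scatter), concerns the same aromatic nitrogen that is changed on the way to compound 4. The change itself is ethoxycarbonyl in place of cyclopropylmethyl on an aromatic nitrogen. For the measured compounds named here, no measured step exchanges a saturated chain substituent for an acyl group on this nitrogen, so the step from compound 2 to compound 3 is the only guide, and it shows that substitution at this nitrogen moves the number by a modest amount. A step of similar size, in either direction, is therefore expected for a 1.3-fold higher number from compound 3 to compound 4 (0.12 log units; within the scatter). Compound 4 is estimated at 80 nM, with a range from 20 nM to 400 nM in this assay.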

Compound 4, half-maximal inhibitory concentration: 12 nM
For compound 4 the middle estimate is 6.7-fold (0.82 log units) above the measured one; measured number below the stated range.
By their numbers in this assay, from the lowest: compounds 4 and 2 (each within the scatter of the next); then compound 3; then compound 1.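

Ethoxycarbonyl in place of cyclopropylmethyl on this aromatic nitrogen gives a 5.1-fold lower number from compound 3 to compound 4 (0.71 log units; beyond the scatter) in this assay and thus reverses the size of the earlier loss seen with a 4.7-fold higher number from compound 2 to compound 3 (0.67 log units; beyond the scatter). Ethoxycarbonyl in place of methyl gives a 1.1-fold lower number from compound 2 to compound 4 (0.03 log units; within the scatter) so, across these three groups, the number does not rise with the count of heavy atoms in the substituent. Nothing available bears on the cause of these steps.

Going by these compounds, whether a longer chain such as butyl or another acyl group such as acetyl on this nitrogen would track methyl and ethoxycarbonyl or cyclopropylmethyl remains open. Also open, on these data alone, is the effect of the bare hydrogen at this nitrogen with the fluoro group kept, since compound 1 differs from the others in a second place as well.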